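Oxazole Ketone Inhibitors: Pyridyl Carboxylic Acid Replacing Nitrophenyl

The source may hold more compounds than are shown below. What is called first, only, known or untested is meant among the compounds shown, and "the series" means these compounds.

Measured compounds:
compound 1 `COC(=O)c1ccccc1-c1cnc(C(=O)CCCCCCc2ccccc2)o1`: 60 nM
compound 2 `O=C(CCCCCCc1ccccc1)c1ncc(-c2ccc([N+](=O)[O-])cc2)o1`: 50 nM
compound 3 `O=C(CCCCCCc1ccccc1)c1ncc(-c2cc(C(F)(F)F)ccn2)o1`: 3.5 nM

In an assay (Rattus norvegicus) for inhibition of Fatty-acid amide hydrolase 1 (Homo sapiens) (on this read-out lower numbers stand for stronger inhibition and higher numbers for weaker inhibition), compound 2 gives 50 nM, the second highest of the three numbers. Its nearest neighbour is compound 1, whose value lies within the scatter of that of compound 2, so no order between the two can be read. Compound 3 stands furthest away, with a number well beyond the scatter below compound 2, so compound 3 is clearly the stronger of that pair.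

Compound 4 `O=C(CCCCCCc1ccccc1)c1ncc(-c2ncccc2C(=O)O)o1` has not yet been measured. It differs from compound 2 by a single rearrangement of the same atoms: 3-carboxypyridin-2-yl in place of 4-nitrophenyl on an aromatic carbon. Among the measured compounds shown here, no measured pair in this set shows this change, so its size can only be estimated. Given that compound 3, which also carries a pyridinyl group, gives 3.5 nM, while compound 1 with a carboxylate ester gives 60 nM, the expected step from compound 2 to compound 4 is a 1.3-fold lower number from compound 2 to compound 4 (0.10 log units; within the scatter), roughly no change beyond the scatter in this assay. Compound 4 is therefore estimated at 40 nM, with a range from 8 nM to 200 nM.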

Compound 4, inhibition constant: > 50 nM
Compound 4 gave a limit, no number; the forecaster's own chance of this, stated with the estimate: 5%; middle value at least 1.2-fold (0.09 log units) away from the limit.
By their numbers in this assay, from the lowest: compound 3; then compounds 2 and 1 (each within the scatter of the next).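

In this assay, placing 3-carboxypyridin-2-yl in place of 4-nitrophenyl on the aromatic carbon next to the ring oxygen gives a number no lower from compound 2 to compound 4 (the limit leaves the size open), so this change brought no measurable gain at this position. The value of compound 4, > 50 nM, is a limit of the assay and not a number. A six-membered aromatic ring with a hetero atom at this position is therefore not enough on its own to match compound 3 at 3.5 nM.

On these data alone, how far compound 4 lies from compound 2 stays open: the limit of > 50 nM in this assay, at which 1 of the 4 values shown sits. The compounds shown also do not separate the part played by the carboxylic acid from that of the ring nitrogen, which a phenyl ring bearing a carboxylic acid or a pyridinyl ring bearing a methyl ester could address.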